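Swapping bromo for methoxy on the aromatic carbon

The compounds below may be only part of what the source reports. "The series", "measured", "known", "first", "only" and "open" are said of these compounds alone.

Measured so far in an ADME assay on HUVEC cells (Homo sapiens) for antiproliferative activity, read by MTT assay, with a stated time of 48 h; on this read-out lower numbers stand for stronger inhibition and higher numbers for weaker inhibition:
compound 1 `Cc1ccccc1-n1nncc1CN1C(=O)C2(C(C#N)=C(N)Oc3c(N)cc4nc5ccccc5nc4c32)c2ccccc21` gives > 50000 nM, which is a limit of the assay and not a number.
compound 2 `N#CC1=C(N)Oc2c(N)cc3nc4ccccc4nc3c2C12C(=O)N(Cc1cnnn1-c1ccccc1Br)c1ccccc12` gives 34200 nM.

For the measured compounds named here, compound 2 therefore supplies the only number in this assay; the one other value is a limit. Compound 3 `COc1ccccc1-n1nncc1CN1C(=O)C2(C(C#N)=C(N)Oc3c(N)cc4nc5ccccc5nc4c32)c2ccccc21` differs from compound 2 by methoxy in place of bromo on an aromatic carbon. Going by the values given here, the only measured step that bears on this change is an at least 1.4-fold lower number from compound 1 to compound 2 (0.16 log units; that floor lies within the scatter), which also exchanges one group for another on an aromatic carbon, and because of the limit of > 50000 nM in this assay, at which 1 of the 2 values shown sits, only a floor on its size is known. That floor lies within the scatter, so replacing bromo with methoxy is expected to move the number little, if at all, in this assay. Compound 3 is accordingly estimated at about 40000 nM, within a range from 15000 nM to 110000 nM. The expected step is a 1.2-fold higher number from compound 2 to compound 3 (0.07 log units; within the scatter).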

Compound 3, half-maximal inhibitory concentration: > 50000 nM
Compound 3 ended at the assay's limit; the forecaster's own chance of this, stated with the estimate: 45%; middle value at least 1.2-fold (0.09 log units) from the limit.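

In this assay compound 3 gives > 50000 nM, which is a limit of the assay and not a number. Replacing bromo with methoxy on this aromatic carbon, ortho to a large group, gives an at least 1.4-fold higher number from compound 2 to compound 3 (0.16 log units; that floor lies within the scatter), so this change has not been shown to alter the result by more than ordinary variation. Compound 1 and compound 3 cannot be ordered against each other, and the step between them cannot be read, for one reason: the limit of > 50000 nM in this assay, at which 2 of the 3 values shown sit.

Still open, as far as these compounds go, is whether an amine or a carboxylic acid on this aromatic carbon would give a number clearly apart from that of compound 2. Equally open, from the compounds shown here alone, is whether a chloro group or a longer chain such as ethoxy would give a readable number here.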